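The source may hold more compounds than are shown below. What is called first, only, known or untested is meant among the compounds shown, and "the series" means these compounds.

Measured compounds: compound 1 `O=C1C(=Cc2ccc(Br)cc2)C(=O)N(c2ccc(Cl)cc2)N1c1ccc(Cl)cc1`, 16900 nM; compound 2 `COc1cc(C=C2C(=O)N(c3ccc(Cl)cc3)N(c3ccc(Cl)cc3)C2=O)cc(OC)c1OC`, 17300 nM; compound 3 `O=C1C(=Cc2ccc(Cl)cc2Cl)C(=O)N(c2ccc(Cl)cc2)N1c1ccc(Cl)cc1`, > 128000 nM.

In a functional assay on MGC-803 cells (Homo sapiens) for cytotoxicity, read by MTT assay, with a stated time of 72 h (a lower number here means a stronger inhibitor, a higher number a weaker inhibitor), compound 1 gives 16900 nM, and compound 2 at 17300 nM sits within the scatter of that, so the two cannot be separated. For compound 3 this assay reports only a limit, > 128000 nM (the limit of > 128000 nM in this assay, at which 1 of the 3 values shown sits). Compound 4 `O=C1C(=Cc2ccc(F)cc2F)C(=O)N(c2ccc(Cl)cc2)N1c1ccc(Cl)cc1` is still unmeasured. It differs from compound 1 in one place: 2,4-difluorophenyl in place of 4-bromophenyl on a double-bonded chain carbon bound to a double-bonded ring carbon. Among the compounds with values here, the only step that bears on this is an at least 7.5-fold higher number from compound 1 to compound 3 (0.87 log units; beyond the scatter), the nearest parallel to the present exchange. A weakening beyond the scatter is therefore expected in this assay, though it may fall short of the step to compound 3. Compound 4 is estimated at 50000 nM, range 18000 nM to 128000 nM. The expected step is a 3.0-fold higher number from compound 1 to compound 4 (0.47 log units; beyond the scatter).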

Compound 4, half-maximal inhibitory concentration: 35700 nM
Compound 4: the middle estimate sits 1.4-fold (0.15 log units) above what was measured, and the stated range covers the measured number.
By their numbers in this assay, from the lowest: compounds 1 and 2 (each within the scatter of the next); then compound 4. At a limit, above all of these: compound 3.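

At this position, a change away from 4-bromophenyl need not cost all measurable activity in this assay: 2,4-difluorophenyl brings only a modest weakening (a 2.1-fold higher number from compound 1 to compound 4 (0.32 log units; beyond the scatter)). The identity of the halogen also counts, with 2,4-difluorophenyl in place of 2,4-dichlorophenyl giving a clear gain (an at least 3.5-fold lower number from compound 3 to compound 4 (0.55 log units; beyond the scatter)). As far as these compounds go, the value for compound 3 is a limit, not a number, so the full size of that gain is unknown: the limit of > 128000 nM in this assay, at which 1 of the 4 values shown sits.

Still open, from the compounds shown here alone, is how a phenyl carrying a single fluorine, or an amine or a carboxylic acid, would behave here. The compounds shown give no cause for the gap between the two halogenated groups.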